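The compounds below may be only part of what the source reports. "The series", "measured", "known", "first", "only" and "open" are said of these compounds alone.

Three compounds with a shared core have been run in an ADME assay on microsomes from liver (Homo sapiens) for metabolic stability, read by LC-MS, using NADPH, with stated times of 5 min and 30 min, tested at 1 uM; on this read-out lower numbers stand for slow clearance and higher numbers for fast clearance. Compound 1 `Cc1ncccc1-c1cnc(NCc2c(F)ccc3c2CCO3)c2nn(CC#N)c(=O)n12` gives 151 mL.min-1.g-1, and compound 3 `CC(=O)N1CCC(c2cnc(NCc3c(F)ccc4c3CCO4)c3cn[nH]c(=O)c23)CC1` gives 207 mL.min-1.g-1. Compound 2 `O=C1c2ccccc2CN1c1cnc(NCc2c(F)ccc3c2CCO3)n2cnnc12` gives 13 mL.min-1.g-1, the lowest of the three numbers: the gap up to compound 1 and the larger gap up to compound 3 both lie well beyond the usual scatter of repeated measurements, so compound 2 is the one cleared most slowly among those measured.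

Compound 4 `O=C1CC2(CC2)CN1c1cnc(NCc2c(F)ccc3c2CCO3)n2cnnc12` has not yet been measured. It differs from compound 2 in one place: a group of 8 heavy atoms (6 carbon, 1 nitrogen, 1 oxygen; one three-membered non-aromatic ring of carbon only, one five-membered non-aromatic ring with 1 hetero atom) in place of a group of 10 heavy atoms (8 carbon, 1 nitrogen, 1 oxygen; one five-membered non-aromatic ring with 1 hetero atom, one six-membered aromatic ring of carbon only), on an aromatic carbon. The group that leaves carries a six-membered aromatic ring of carbon only, while the group that enters carries a three-membered non-aromatic ring of carbon only in its place, each sitting on a five-membered non-aromatic ring with one hetero atom.

Among the measured compounds shown here, no pair of measured compounds shows this exchange, so the expectation rests on compound 2 alone. The step from compound 2 to compound 4 in this assay is estimated as a 1.9-fold higher number from compound 2 to compound 4 (0.28 log units; within the scatter), a modest rise that may not exceed the scatter. Compound 4 is therefore expected to give about 25 mL.min-1.g-1, with a likely range from 8 mL.min-1.g-1 to 80 mL.min-1.g-1.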

Compound 4, intrinsic clearance in microsomes: < 3 mL.min-1.g-1
Compound 4 ended at the assay's limit; the forecaster's own chance of this, stated with the estimate: 5%; middle value at least 8.3-fold (0.92 log units) away from the limit.
By their numbers in this assay, from the lowest: compound 2; then compounds 1 and 3 (each within the scatter of the next). At a limit, below all of these: compound 4.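

In this assay, setting a group with a three-membered non-aromatic ring of carbon only in place of one with a six-membered aromatic ring of carbon only gives an at least 4.3-fold lower number from compound 2 to compound 4 (0.63 log units; beyond the scatter), a step beyond the scatter on an aromatic carbon that already carried the compound with the lowest number. Among the compounds shown here, this is the first measured step at this place, and it shows that the number there still depends on the group attached, and that the six-membered aromatic ring of carbon only is not required for a low number. Compound 4 stands at a limit of the assay, not at a number, so the printed step gives only the smallest size the change can have: the limit of < 3 mL.min-1.g-1 in this assay, at which 1 of the 4 values shown sits.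

The compounds shown leave open whether the lower number follows from losing the six-membered aromatic ring of carbon only or from gaining the three-membered ring. Two methyl groups in place of the three-membered ring, or the same five-membered ring with no further carbon ring on it, would separate these two readings.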